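Amide aryl variation on the shared core: a nitrophenyl step

This account rests on a few compounds, and the source may have more. Where it says the series, first, only, none or still open, it means among the compounds named here.

Compound 2 `O=C(Nc1ccc(Cl)cc1)c1c(O)c2cccnc2n(-c2ccccc2)c1=O` stands highest of the two numbers in a functional assay on the whole organism for inhibition, with Rattus norvegicus as the target, read by paw edema, at a dose of 100 mg/kg by the oral route (on this read-out lower numbers stand for less inhibition and higher numbers for more inhibition at the one dose given (going by the name of the read-out)), giving 11.6%, while compound 1 `O=C(Nc1ccccn1)c1c(O)c2cccnc2n(-c2ccccc2)c1=O` gives -13.5%. Within the data shown here, the one measured step, a number 25.1 percentage points higher from compound 1 to compound 2 (beyond the scatter), concerns 4-chlorophenyl in place of pyridin-2-yl on an amide-type nitrogen. Compound 3 `O=C(Nc1cccc([N+](=O)[O-])c1)c1c(O)c2cccnc2n(-c2ccccc2)c1=O` differs from compound 2 by 3-nitrophenyl in place of 4-chlorophenyl on an amide-type nitrogen. Among the measured compounds shown here, no measured step exchanges one six-membered aromatic ring of carbon only for another, so the step from compound 1 to compound 2 bears on it only loosely. The expected change is a number 3.6 percentage points lower from compound 2 to compound 3 (within the scatter), within the scatter. Compound 3 is estimated at 8%, ranging from -15% to 30%.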

Compound 3, a percentage reported as inhibition, in the whole organism at one dose (the size of the read-out at that dose, not a potency): 5.7%
For compound 3 the middle estimate is 2.3 percentage points above the measured one; the range from low to high includes it.
By their numbers in this assay, from the lowest: compound 1; then compounds 3 and 2 (each within the scatter of the next).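

In this assay the step of a number 5.9 percentage points lower from compound 2 to compound 3 (within the scatter) shows that exchanging 4-chlorophenyl for 3-nitrophenyl on the amide-type nitrogen gives no readable change. The step of a number 19.2 percentage points higher from compound 1 to compound 3 (beyond the scatter) shows that a second aryl group with a six-membered aromatic ring of carbon only also stands clear of the pyridin-2-yl amide, so compound 1 lies apart from both compound 2 and compound 3. No measurement available here explains either step.

Still open, from the compounds shown here alone, is whether an amine or a carboxylic acid on the phenyl ring would shift the number beyond the scatter. Also open, going by these compounds, is whether a saturated chain in place of the aryl group on this nitrogen would keep the level of compound 2 and compound 3.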